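A few compounds are considered here, and "the series" means these few. Any claim that something is new, unique, unknown or untested is made for them only; others in the source may bear on it.

Measured so far:
- compound 1 `Cc1nc(C)n2c(=O)n(C)ncc12` — in a functional assay for inhibition, with Homo sapiens as the target (a higher number here means a weaker inhibitor, a lower number a stronger inhibitor), compound 1 gives only the limit > 48000 nM.
- compound 2 `C=CCn1ncc2c(C)nc(C(C)C)n2c1=O` — in this assay compound 2 gives only the limit > 48000 nM.

Among the measured compounds shown here, compound 2 therefore stands nowhere on a numerical scale: its result in this assay is a limit, and the one further value shown, that of compound 1, is a limit as well. Both sit at the same point, as noted in the limit of > 48000 nM in this assay, at which 2 of the 2 values shown sit. For the measured compounds named here, no step between measured compounds is available.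

Compound 3 `C=CCn1ncc2c(C)nc(C)n2c1=O` carries the change (methyl in place of isopropyl on an aromatic carbon), a methyl in place of isopropyl on an aromatic carbon. Compound 1 carries methyl at the same place and still returns a limit, so no step beyond the scatter is expected in this assay in either direction. The expected step that the limit leaves unreadable from compound 2 to compound 3 is essentially none. Compound 3 is estimated at 70000 nM, within 25000 nM to 250000 nM, most likely reported again as a limit.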

Compound 3, half-maximal inhibitory concentration: 73000 nM
Compound 3: the middle estimate sits 1.0-fold (0.02 log units) below what was measured; low and high end bracket the measured number.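

Compound 3 has a number in this assay, but compound 1 and compound 2 have only limits, so neither step to compound 3 can be read: the limit of > 48000 nM in this assay, at which 2 of the 3 values shown sit. The compounds shown leave open the size of either change, methyl in place of isopropyl or vinyl in place of hydrogen, in this assay.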